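Working notes: ether-to-amide exchange on the shared core

The source may hold more compounds than are shown below. What is called first, only, known or untested is meant among the compounds shown, and "the series" means these compounds.

Measured compounds:
compound 1 `Cc1nn(-c2ncnc3nc[nH]c23)c2c1C(OCc1ccccc1F)CC(=O)N2` – 78 nM
compound 2 `Cc1nn(-c2ncnc3nc[nH]c23)c2c1C(OCc1ccccc1C#N)CC(=O)N2` – 127 nM
compound 3 `Cc1nn(-c2ncnc3nc[nH]c23)c2c1C(OCc1ccc(C(C)C)cc1)CC(=O)N2` – 1690 nM

In a functional assay on HEK293 cells for agonist activity at G-protein coupled receptor 39 (Homo sapiens), read by scintillation proximity assay and inositol phosphate accumulation, with a stated time of 75 min (on this read-out higher numbers stand for an effect only at larger amounts of compound and lower numbers for an effect already at smaller amounts), compound 2 gives 127 nM, the second highest of the three numbers. The nearest number belongs to compound 1: the step of a 1.6-fold higher number from compound 1 to compound 2 (0.21 log units; within the scatter) lies within the scatter, so the two cannot be ordered. The furthest belongs to compound 3: the step of a 13-fold higher number from compound 2 to compound 3 (1.12 log units; beyond the scatter) is large and beyond the scatter, as is a 22-fold higher number from compound 1 to compound 3 (1.34 log units; beyond the scatter).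

Compound 4 `Cc1nn(-c2ncnc3nc[nH]c23)c2c1C(NC(=O)Cc1cccs1)CC(=O)N2` differs from compound 2 by (((thiophen-2-yl)methyl)carbonyl)amino in place of (2-cyanobenzyl)oxy on a saturated ring carbon. For the measured compounds named here, no measured step touches the linking oxygen; the measured steps alter only the aryl part and its substituents, yet two of them move the number a lot. The change to compound 4 goes further than any of these, exchanging both the linker and the aromatic ring, so a step beyond the scatter in this assay is expected, with the direction uncertain and the higher-number side weighted somewhat more, given that the steps of a 22-fold higher number from compound 1 to compound 3 (1.34 log units; beyond the scatter) and a 13-fold higher number from compound 2 to compound 3 (1.12 log units; beyond the scatter) both ran that way when the aryl part was changed.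

Compound 4 is therefore expected at 350 nM, with a range from 60 nM to 2500 nM. The expected step is a 2.8-fold higher number from compound 2 to compound 4 (0.44 log units; beyond the scatter).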

Compound 4, half-maximal effective concentration: 244 nM
Compound 4: middle estimate off by 1.4-fold (0.16 log units), on the high side, and the stated range covers the measured number.
By their numbers in this assay, from the lowest: compounds 1, 2 and 4 (each within the scatter of the next, the first and the last beyond it); then compound 3.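

The exchange at this saturated ring carbon is the first change shown that removes the linking oxygen, and in this assay (((thiophen-2-yl)methyl)carbonyl)amino in place of (2-cyanobenzyl)oxy gives a 1.9-fold higher number from compound 2 to compound 4 (0.28 log units; within the scatter). That step stays within the scatter, so compound 4 cannot be ordered against compound 2, even though the linker and the aromatic ring both change and a hydrogen-bond donor enters. For the compounds shown here, the same replacement of (2-fluorobenzyl)oxy gives a 3.1-fold higher number from compound 1 to compound 4 (0.50 log units; beyond the scatter), a modest step beyond the scatter, so the position holds an amide-linked thiophene without the large rise printed for compound 3 at 1690 nM, while the series has only a single example of this linker.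

As far as these compounds go, with the linker and the aromatic ring exchanged together, the share of each in these numbers cannot be separated, and how a free amine, a carboxylic acid or a longer chain between the carbonyl and the thiophene would read at this ring carbon stays open. Nothing at hand accounts for the numbers at this position.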